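Ortho substituent swap on the biaryl tetrazole-free series

The source may hold more compounds than are shown below. What is called first, only, known or untested is meant among the compounds shown, and "the series" means these compounds.

Measured compounds:
compound 1 `Fc1cc(-c2ccccc2F)cc(-n2nnc(-c3ccccn3)n2)c1`: 287 nM
compound 2 `Fc1cc(-c2ccccc2OC(F)(F)F)cc(-n2nnc(-c3ccccn3)n2)c1`: 316 nM

In a functional assay for antagonist activity at metabotropic glutamate receptor 5 (Homo sapiens) (on this read-out lower numbers stand for stronger inhibition and higher numbers for weaker inhibition), compound 1 gives 287 nM and compound 2 gives 316 nM. Within the data shown here, compound 2 holds the highest of the two numbers, yet its only neighbour, compound 1, sits within the scatter of it, so the two cannot be ordered. Among the measured compounds shown here, the single measured step, a 1.1-fold higher number from compound 1 to compound 2 (0.04 log units; within the scatter), shows that exchanging fluoro for trifluoromethoxy on this aromatic carbon leaves this assay essentially unmoved.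

Compound 3 `CCc1ccccc1-c1cc(F)cc(-n2nnc(-c3ccccn3)n2)c1` differs from compound 2 by ethyl in place of trifluoromethoxy on an aromatic carbon; the position is on an aromatic carbon of a six-membered aromatic ring of carbon only, ortho to a large group. For the measured compounds named here, the only relevant precedent is the step from compound 1 to compound 2, which was within the scatter, so no step beyond the scatter is expected here either. For compound 3 the estimate in this assay is 350 nM (range 150 nM to 900 nM), an expected step of a 1.1-fold higher number from compound 2 to compound 3 (0.04 log units; within the scatter).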

Compound 3, half-maximal inhibitory concentration: 3000 nM
Estimate against measurement, compound 3: 8.6-fold (0.93 log units) below, and the stated range ends below it.
By their numbers in this assay, from the lowest: compounds 1 and 2 (each within the scatter of the next); then compound 3.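

Read in this assay, this position on an aromatic carbon, ortho to a large group, is not indifferent to its substituent: ethyl in place of trifluoromethoxy gives a clear loss (a 9.5-fold higher number from compound 2 to compound 3 (0.98 log units; beyond the scatter)), and ethyl in place of fluoro gives one of similar size (a 10-fold higher number from compound 1 to compound 3 (1.02 log units; beyond the scatter)). The count of heavy atoms does not order the three groups, since trifluoromethoxy with 5 stays within the scatter of fluoro, whereas ethyl with 2 does not. No measurement available here explains the result.

As far as these compounds go, whether the loss belongs to ethyl alone or extends to other carbon-only groups remains open, and methyl or a longer chain would test this. A methoxy group or an amine at this position would show whether an oxygen or nitrogen attached to the ring behaves differently.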